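The compounds below may be only part of what the source reports. "The series", "measured", "known", "first", "only" and "open" are said of these compounds alone.

In a functional assay (plasma) for inhibition, with Rattus norvegicus as the target (a higher number here means a weaker inhibitor, a lower number a stronger inhibitor), compound 1 (`O=C(NCc1cc(Cl)ccc1-n1cnnn1)[C@@H]1CC=NN1C(=O)[C@H](O)c1ccccc1`) gives 120 nM and compound 3 (`CCCC[C@@H](O)C(=O)N1N=CC[C@H]1C(=O)NCc1cc(Cl)ccc1-n1cnnn1`) gives 240 nM on the same read-out. Compound 2 (`O=C(NCc1cc(Cl)ccc1-n1cnnn1)[C@@H]1C[C@H]2C[C@H]2N1C(=O)[C@H](O)c1ccccc1`) gives 25 nM as the lowest number of the three, beyond the scatter from both compound 1 and compound 3. Compound 4 (`O=C(NCc1cc(Cl)ccc1-n1cnnn1)[C@@H]1C[C@@H]2C[C@@H]2N1C(=O)[C@H](O)c1ccccc1`) is the next to be read, and its change from compound 2 is one of configuration alone: the two compounds have the same atoms and bonds and differ only in configuration as drawn: 2 of 4 stereo elements differ; a stereocentre at a saturated ring carbon is drawn R in compound 2 and S in compound 4; a stereocentre at a saturated ring carbon is drawn R in compound 2 and S in compound 4 is the whole of it, with nothing leaving and nothing entering.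

Among the compounds with values here, the one measured step, a 2.0-fold higher number from compound 1 to compound 3 (0.30 log units; within the scatter) for butyl in place of phenyl, concerns the side chain and says nothing directly about configuration at saturated ring carbons. Within the data shown here, no measured pair differs in configuration alone, so the direction rests on thin evidence. Compound 2 at 25 nM sits at the low end of the series, while compound 1 at 120 nM has a different core and stands higher. A move to a higher number is therefore expected in this assay with wide uncertainty. For compound 4 the expected value is 90 nM within an estimated range of 20 nM to 400 nM on this evidence. This estimate means an expected 3.6-fold higher number from compound 2 to compound 4 (0.56 log units; beyond the scatter) on that read-out.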

Compound 4, half-maximal inhibitory concentration: 150 nM
Compound 4: middle estimate off by 1.7-fold (0.22 log units), on the low side; low and high end bracket the measured number.
By their numbers in this assay, from the lowest: compound 2; then compounds 1, 4 and 3 (each within the scatter of the next).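

In this assay, the series now holds a step that turns on configuration alone: a 6.0-fold higher number from compound 2 to compound 4 (0.78 log units; beyond the scatter). Within the data shown here, the only earlier step, a 2.0-fold higher number from compound 1 to compound 3 (0.30 log units; within the scatter), concerned the side chain and stayed within the scatter, so the configuration of the two saturated ring carbons, drawn R in compound 2 and S in compound 4, is the first change here with a step beyond the scatter. This step can be assigned to those two stereocentres and to no change of atoms or bonds because of a single fact: the fact that compounds 2 and 4 differ only in the configuration as drawn.

Both stereocentres change together in this pair, which leaves open whether one of them alone carries the step or both contribute to it. Also open, on these data alone, is whether the same gap between the two configurations holds with butyl in place of phenyl, or with a carboxylic acid or an amine on a longer chain at that place.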